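This account rests on a few compounds, and the source may have more. Where it says the series, first, only, none or still open, it means among the compounds named here.

Of the compounds shown here, three have been tested in a functional assay on Hep 3B2 cells (Homo sapiens) for antiproliferative activity, read by MTT assay, with a stated time of 24 h, tested at 0.02 ug/mL; a higher number here means a stronger effect of the compound at the concentration tested, a lower number a weaker effect. Compound 1 `Cc1c(C(=O)Nc2c(F)cc(-c3cccc(F)c3)cc2F)nc2ccc(F)cc2c1O` gives 0.35% in this assay. Compound 3 `Cc1c(C(=O)Nc2c(F)cc(-c3cccc(F)c3)cc2F)nc2ccc(F)cc2c1C(=O)O` shares the core of compound 1 and differs from it only by carboxy in place of hydroxy on an aromatic carbon. In this assay compound 3 gives -0.13%, and the step of a number 0.5 percentage points lower from compound 1 to compound 3 (within the scatter) lies within the usual scatter of the measurement. Compound 2 `COc1ccc2nc(C(=O)Nc3ccc(-c4ccccc4)cc3)c(C)c(O)c2c1` carries a different core; how it differs from compound 1 is not broken down here. In this assay compound 2 gives 0.96%. The values of compound 1, compound 2 and compound 3 all lie within the scatter of one another, so none of the three can be set apart from the others.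

Compound 4 `COc1ccc2nc(C(=O)Nc3ccc(-c4ccccc4)cc3)c(C)c(C(=O)O)c2c1` has not yet been measured. For the measured compounds named here, it differs from compound 2 by carboxy in place of hydroxy on an aromatic carbon, which is the same change as the one made from compound 1 to compound 3, at the same place on the ring. The expected step of a number 0.5 percentage points lower from compound 2 to compound 4 (within the scatter) is estimated to be small, since it rests on the measured step of a number 0.5 percentage points lower from compound 1 to compound 3 (within the scatter) and on the value of compound 2, 0.96%. Compound 4 is therefore expected to give 0.5% in this assay, with an estimated range from -4% to 5%.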

Compound 4, a percentage reported as inhibition, at one concentration (the size of the read-out at that concentration, not a potency): 0.05%
Compound 4: the middle estimate sits 0.5 percentage points above what was measured, and the stated range covers the measured number.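

On the second core, carboxy in place of hydroxy on an aromatic carbon gives a number 0.9 percentage points lower from compound 2 to compound 4 (within the scatter) in this assay, and the two steps now available for this change cannot be told apart: the same change on two cores in this assay, a number 0.5 percentage points lower (within the scatter) from compound 1 to compound 3 and a number 0.9 percentage points lower (within the scatter) from compound 2 to compound 4, 0.4 percentage points apart, within the scatter of two such steps.

The change therefore behaves alike on the two cores only in a limited sense: on neither core does it give a step that stands out from the scatter of the measurement. This does not show that the change has an effect of its own on either core, nor that a step of clear size on one core would carry over to the other, since with every step inside the scatter, the agreement between them rests on no measurable effect and the test of transfer remains a weak one.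

The compounds shown leave open whether a different group on this aromatic carbon opposite the ring nitrogen, such as an amine, a primary amide or a longer chain, would give a number beyond the scatter. They also leave open how any of these compounds would read at other concentrations, and whether the methyl group that carboxy and hydroxy sit ortho to could be replaced by an ethyl group without a change in the number.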